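Aryl replacement at the ring amine: outlook for compound 3

This account rests on a few compounds, and the source may have more. Where it says the series, first, only, none or still open, it means among the compounds named here.

Compound 2 `CCCc1nc(-c2ccccc2)c(CNCCN2CCN(c3ccc(F)cc3)CC2)o1` gives 7080 nM in an assay on HEK293 cells for inhibition of Voltage-dependent T-type calcium channel subunit alpha-1G (Homo sapiens), read by patch clamp (on this read-out higher numbers stand for weaker inhibition and lower numbers for stronger inhibition), the highest of the two numbers in hand. Within the data shown here, compound 1 `CCCc1nc(-c2ccccc2)c(CNCCN2CCN(c3ccc(Cl)cc3)CC2)o1` sits at 2820 nM, and the only measured step is a 2.5-fold higher number from compound 1 to compound 2 (0.40 log units; beyond the scatter). Compound 3 `CCCc1nc(-c2ccccc2)c(CNCCN2CCN(c3ccccc3C(F)(F)F)CC2)o1` differs from compound 2 by 2-(trifluoromethyl)phenyl in place of 4-fluorophenyl on an amine nitrogen in a ring. Among the measured compounds shown here, that halogen step touches the same place but a different group, so no measured step covers the entering 2-(trifluoromethyl)phenyl. For compound 3 the expected step is a 1.8-fold lower number from compound 2 to compound 3 (0.25 log units; within the scatter), possibly not beyond the scatter. Compound 3 is estimated at 4000 nM, expected between 1500 nM and 12000 nM.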

Compound 3, half-maximal inhibitory concentration: 2100 nM
Compound 3: the middle estimate sits 1.9-fold (0.28 log units) above what was measured; the measured number falls inside the stated range.
By their numbers in this assay, from the lowest: compounds 3 and 1 (each within the scatter of the next); then compound 2.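

Swapping 4-fluorophenyl for 2-(trifluoromethyl)phenyl on the ring amine nitrogen gives a 3.4-fold lower number from compound 2 to compound 3 (0.53 log units; beyond the scatter) and shows that this position responds to a change of the whole aryl group, not only to a halogen swap. With 4-chlorophenyl as the starting point, the same entering group gives a 1.3-fold lower number from compound 1 to compound 3 (0.13 log units; within the scatter) and so does not separate the two aryl groups on this read-out. No measurement on hand gives a reason for either step.

From the compounds shown here alone, how a plain phenyl, or a phenyl carrying a nitrile or a carboxylic acid, would read at this amine nitrogen remains open. So does the effect of any change elsewhere on the shared core.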